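Methyl heteroaryl swaps on the shared core: one more step

The source may hold more compounds than are shown below. What is called first, only, known or untested is meant among the compounds shown, and "the series" means these compounds.

In an ADME assay on the whole organism for pharmacokinetics, with Rattus norvegicus as the target, at a dose of 1 mg/kg by the oral route (a lower number here means that a smaller share of the oral dose reaches the circulation, a higher number that a larger share of the oral dose reaches the circulation), compound 1 `COc1ccc(C(=O)C2=C(O)C(=O)N(c3ccc(-c4noc(C)n4)cc3)C2C2CCCCC2)cc1` gives 7.1% as the first reference point. Compound 2 `COc1ccc(C(=O)C2=C(O)C(=O)N(c3ccc(-c4nc(C)no4)cc3)C2C2CCCCC2)cc1` gives 13.5% on the same core, and the step between these two is a number 6.4 percentage points higher from compound 1 to compound 2 (within the scatter) and carries little weight. Compound 3 `COc1ccc(C(=O)C2=C(O)C(=O)N(c3ccc(-c4nnc(C)o4)cc3)C2C2CCCCC2)cc1` gives 2.9% and cannot be separated from compound 1 (a number 4.2 percentage points lower from compound 1 to compound 3 (within the scatter)), while it stands under compound 2 (a number 10.6 percentage points lower from compound 2 to compound 3 (beyond the scatter)).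

Compound 4 `COc1ccc(C(=O)C2=C(O)C(=O)N(c3ccc(-c4cc(C)no4)cc3)C2C2CCCCC2)cc1` differs from compound 3 by 3-methyl-1,2-oxazol-5-yl in place of 5-methyl-1,3,4-oxadiazol-2-yl on an aromatic carbon on an aromatic carbon of a six-membered aromatic ring of carbon only, para to a large group. Among the measured compounds shown here, no measured step covers the entering ring directly, so the three swaps at this same place are the only guide. Two of them stay inside the scatter, and the one that leaves it, a number 10.6 percentage points lower from compound 2 to compound 3 (beyond the scatter), is modest. Among the measured groups, the name of the entering group lies closest to that of compound 2 at 13.5%, which gives a weak lean upward. The expected step is a number 7.1 percentage points higher from compound 3 to compound 4 (within the scatter) and its direction remains tentative. For compound 4 the estimated value is 10%, with an expected range from 3% to 22% as the likely span.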

Compound 4, oral bioavailability: 0.5%
Compound 4: the middle estimate sits 9.5 percentage points above what was measured; measured number below the stated range.
By their numbers in this assay, from the lowest: compounds 4, 3, 1 and 2 (each within the scatter of the next, the first and the last beyond it).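

In this assay, the change to 3-methyl-1,2-oxazol-5-yl, one five-membered aromatic ring with 2 hetero atoms in place of one with 3, gives a number 2.4 percentage points lower from compound 3 to compound 4 (within the scatter) and a number 6.6 percentage points lower from compound 1 to compound 4 (within the scatter), so this swap cannot be separated from either compound 3 or compound 1. The step that does leave the scatter, a number 13 percentage points lower from compound 2 to compound 4 (beyond the scatter), joins a number 10.6 percentage points lower from compound 2 to compound 3 (beyond the scatter), so the 3-methyl-1,2,4-oxadiazol-5-yl group now stands apart from two of the other three rings, although a number 6.4 percentage points higher from compound 1 to compound 2 (within the scatter) still keeps it inseparable from compound 1. The hetero atom count alone does not sort the series: compound 3, with 3 hetero atoms in its ring, stands apart from compound 2 yet cannot be separated from compound 4, with 2.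

As far as these compounds go, it remains open whether a group of another kind at this place, such as a carboxylic acid, an amine or a longer chain, would give a larger share of the oral dose in the circulation than any of these methyl-bearing rings. No measurement at hand explains why these ring swaps differ in oral bioavailability.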